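The source may hold more compounds than are shown below. What is called first, only, known or untested is meant among the compounds shown, and "the series" means these compounds.

Series so far, all in a functional assay on HUVEC cells (Homo sapiens) for antiproliferative activity (on this read-out lower numbers stand for stronger inhibition and higher numbers for weaker inhibition), as the read-out:
- compound 1 `CC(C)c1c(-c2nnc(N(C)C)o2)cn2ncnc(Nc3cc(C(=O)NC4CC4)c(F)cc3F)c12` with "not determined" (no result reported) as its entry
- compound 2 `CC(C)c1c(-c2nnc(NCC(C)(C)CN)o2)cn2ncnc(Nc3cc(C(=O)NC4CC4)c(F)cc3F)c12` with "not determined" (no result reported) as its entry
- compound 3 `CNCCCNc1nnc(-c2cn3ncnc(Nc4cc(C(=O)NC5CC5)c(F)cc4F)c3c2C(C)C)o1` with 62 nM as its entry

For the measured compounds named here, compound 3 at 62 nM holds the only number in the set, so it cannot be ranked against anything. Neither compound 1 nor compound 2 offers a comparison.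

Next in line is compound 4 `CC(C)c1c(-c2nnc(OCC3CCNCC3)o2)cn2ncnc(Nc3cc(C(=O)NC4CC4)c(F)cc3F)c12`, which carries (piperidin-4-yl)methoxy in place of (3-(methylamino)propyl)amino on an aromatic carbon of the five-membered aromatic ring. The counted change is (piperidin-4-yl)methoxy in place of (3-(methylamino)propyl)amino on an aromatic carbon and the rest of the structure stays the same.

Going by the values given here, no measured pair shows what a change at this place does, so the expectation rests on compound 3 at 62 nM alone, and the range stays wide. The expected 1.0-fold lower number from compound 3 to compound 4 (0.01 log units; within the scatter) in this assay is none beyond the scatter, with no direction favoured. For compound 4 the estimated value is 60 nM within an expected range from 15 nM to 240 nM pending measurement.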

Compound 4, half-maximal inhibitory concentration: 25 nM
Beside the measured number, compound 4's estimate is 2.4-fold (0.38 log units) above it; the range from low to high includes it.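

In this assay, for the compounds shown here, the first readable step at this position is a 2.5-fold lower number from compound 3 to compound 4 (0.39 log units; beyond the scatter), so this carbon of the five-membered aromatic ring accepts a group with a six-membered non-aromatic ring as well as the open (3-(methylamino)propyl)amino chain, and the number improves modestly. The change replaces the chain and its linking nitrogen with (piperidin-4-yl)methoxy in a single step, so this pair cannot separate the effect of the ring from that of the linking oxygen. No available evidence bears on the reason for this step.

A (piperidin-4-yl)methylamino group would test the linking atom alone, while a 3-(methylamino)propoxy chain would test the ring alone. From the compounds shown here alone, whether a carboxylic acid on the same carbon keeps this level of inhibition also remains open.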